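This account rests on a few compounds, and the source may have more. Where it says the series, first, only, none or still open, it means among the compounds named here.

Compound 3 `N#Cc1cnc(NCc2cnccc2C(F)(F)F)cc1NCCC1CCOCC1` gives the highest number of the three measured compounds in an assay on isolated protein for inhibition of protein kinase C theta type (Homo sapiens), read by TR-FRET, with a stated time of 2 h; on this read-out higher numbers stand for weaker inhibition and lower numbers for stronger inhibition: compound 3 gives 1200 nM. Compound 1 `N#Cc1cnc(NCc2cnccc2C(F)(F)F)cc1N[C@H]1CC[C@@H](O)CC1` gives 100 nM in this assay, and compound 2 `N#Cc1cnc(NCc2cnccc2C(F)(F)F)cc1NC[C@H]1CC[C@H](O)CC1` gives 50 nM. The two measured steps that lead to compound 3 are both large: a 12-fold higher number from compound 1 to compound 3 (1.08 log units; beyond the scatter) and a 24-fold higher number from compound 2 to compound 3 (1.38 log units; beyond the scatter). The step between compound 1 and compound 2 is a 2.0-fold lower number from compound 1 to compound 2 (0.30 log units; within the scatter).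

Compound 4 `CC1(C)C[C@H](Nc2cc(NCc3cnccc3C(F)(F)F)ncc2C#N)CC[C@H]1O` differs from compound 3 in one place: 4-hydroxy-3,3-dimethylcyclohexyl in place of 2-(oxan-4-yl)ethyl on a nitrogen on an aromatic ring. This change takes away the 2-(oxan-4-yl)ethyl group that accompanies the weak number of compound 3 and puts in its place a 4-hydroxy-3,3-dimethylcyclohexyl group, which resembles the 4-hydroxycyclohexyl of compound 1 but carries two further methyl groups. The step from compound 1 to compound 3, a 12-fold higher number from compound 1 to compound 3 (1.08 log units; beyond the scatter), bears most directly on this, and in reverse it suggests a large drop in number. For the measured compounds named here, the two added methyl groups have no counterpart among the measured compounds, so their effect cannot be read from the data.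

The author therefore expects a large step downward in this assay, a 10-fold lower number from compound 3 to compound 4 (1.00 log units; beyond the scatter), and estimates that compound 4 will give about 120 nM, within a range from 35 nM to 450 nM.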

Compound 4, half-maximal inhibitory concentration: 100 nM
Compound 4: the middle estimate sits 1.2-fold (0.08 log units) above what was measured; measured number inside the range.
By their numbers in this assay, from the lowest: compounds 2, 1 and 4 (each within the scatter of the next); then compound 3.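

On a nitrogen on an aromatic ring, the two further methyl groups of the 4-hydroxy-3,3-dimethylcyclohexyl group leave the read-out of this assay at the level of the plain 4-hydroxycyclohexyl group (no change at the digits printed from compound 1 to compound 4 (within the scatter)), and this group also stays within the scatter of the (4-hydroxycyclohexyl)methyl group (a 2.0-fold higher number from compound 2 to compound 4 (0.30 log units; within the scatter)). For the compounds shown here, replacing the 2-(oxan-4-yl)ethyl group with it gives a large step (a 12-fold lower number from compound 3 to compound 4 (1.08 log units; beyond the scatter)), so the three compounds with a hydroxyl-bearing cyclohexyl group now form one group within the scatter, and compound 3, the only one with an oxan-4-yl ring, stands apart from all of them. Nothing given here accounts for this result.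

The compounds shown leave open whether the hydroxyl itself matters, since no 4-aminocyclohexyl, 4-methoxycyclohexyl or 4-carboxycyclohexyl group appears among them to separate it from the carbon-only ring. They also leave open how a longer chain such as 2-(4-hydroxycyclohexyl)ethyl, or the opposite arrangement of the two defined stereocentres in the 4-hydroxy-3,3-dimethylcyclohexyl group, would read in this assay.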